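Cytotoxicity of one shared core on Vero cells

A few compounds are considered here, and "the series" means these few. Any claim that something is new, unique, unknown or untested is made for them only; others in the source may bear on it.

Three compounds share one core. Compound 1 `N/C(=N/NC(CC(=O)c1ccc(-n2ccnc2)cc1)c1ccccc1[N+](=O)[O-])c1ccccn1` gives 48000 nM in an ADME assay on Vero cells (Chlorocebus sabaeus) for cytotoxicity, read by MTT assay, with a stated time of 72 h; on this read-out lower numbers stand for higher toxicity in this test and higher numbers for lower toxicity in this test. Compound 2 `N/C(=N/NC(CC(=O)c1ccc(-n2ccnc2)cc1)c1ccccc1Cl)c1ccccn1` gives 53200 nM in this assay, and compound 3 `N/C(=N/NC(CC(=O)c1ccc(-n2ccnc2)cc1)c1ccc(Cl)cc1Cl)c1ccccn1` gives 27800 nM. Compound 3 holds the lowest of the three numbers, yet its gaps to the other two stay within the scatter. Compound 4 `N/C(=N/NC(CC(=O)c1ccc(-n2ccnc2)cc1)c1cccc([N+](=O)[O-])c1)c1ccccn1` differs from compound 3 in one place: 3-nitrophenyl in place of 2,4-dichlorophenyl on a saturated chain carbon bound to an amine nitrogen and a saturated chain carbon. The measured steps that bear on it all exchange nitro and chloro groups at the part of the molecule that changes here: a 1.1-fold higher number from compound 1 to compound 2 (0.04 log units; within the scatter), a 1.7-fold lower number from compound 1 to compound 3 (0.24 log units; within the scatter) and a 1.9-fold lower number from compound 2 to compound 3 (0.28 log units; within the scatter), each within the scatter. The change to compound 4 is therefore expected to give a step of a 1.4-fold higher number from compound 3 to compound 4 (0.16 log units; within the scatter), nothing beyond the scatter. Compound 4 is estimated at 40000 nM, within 20000 nM to 80000 nM.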

Compound 4, half-maximal cytotoxic concentration: 28700 nM
Beside the measured number, compound 4's estimate is 1.4-fold (0.14 log units) above it, within the range that was stated.
By their numbers in this assay, from the lowest: compounds 3, 4, 1 and 2 (each within the scatter of the next).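

Three new steps in this assay all stay within the scatter: (a 1.0-fold higher number from compound 3 to compound 4 (0.01 log units; within the scatter)), (a 1.9-fold lower number from compound 2 to compound 4 (0.27 log units; within the scatter)) and (a 1.7-fold lower number from compound 1 to compound 4 (0.22 log units; within the scatter)). The last step shows something new: 3-nitrophenyl in place of 2-nitrophenyl, a change in where the nitro group sits, gives no readable difference at this saturated chain carbon, just as the exchanges of nitro and chloro groups gave none. No available evidence explains this. Every group shown here is a phenyl ring bearing nitro or chloro. From the compounds shown here alone, an amine or a carboxylic acid on that ring, or a longer chain in its place, remains open.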